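The source may hold more compounds than are shown below. What is called first, only, known or untested is meant among the compounds shown, and "the series" means these compounds.

Measured in a functional assay on SW480 cells (Homo sapiens) for antiproliferative activity, read by MTT assay, with a stated time of 48 h; a higher number here means a weaker inhibitor, a lower number a stronger inhibitor
compound 1 `CCCCCCCCC(CCO)n1cnc2c(NC)ncnc21` gives 3770 nM
compound 2 `CCCCCCCCCCC(CCO)n1cnc2c(Cl)ncnc21` gives 3160 nM

On these numbers, compound 2 stands level with compound 1: their two values lie within the usual scatter of each other, so neither can be called the better inhibitor. The next compound, compound 3 `CCCCCCCCCCC(CCO)n1cnc2c(NC)ncnc21`, has not yet been measured. It comes from compound 2 through a single change, methylamino in place of chloro on an aromatic carbon with methylamino in place of chloro on an aromatic carbon of the shared core.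

Going by the values given here, no measured pair shows this swap alone, so any expectation remains loose. The best guide is that compound 3 shares its methylamino group with compound 1, which gives 3770 nM and differs from it only in the chain. Compound 2 gives 3160 nM with the chain of compound 3 and the chloro group. Both values point to a similar level, so no step beyond the scatter is expected. In this assay the expected step is a 1.1-fold lower number from compound 2 to compound 3 (0.02 log units; within the scatter) and its direction remains uncertain. Compound 3 is estimated at 3000 nM with 1200 nM to 7000 nM as its expected range.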

Compound 3, half-maximal inhibitory concentration: 12000 nM
For compound 3 the middle estimate is 4.0-fold (0.60 log units) below the measured one; measured number outside the range, above it.
By their numbers in this assay, from the lowest: compounds 2 and 1 (each within the scatter of the next); then compound 3.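

In this assay, the change from chloro to methylamino on an aromatic carbon of the shared core can now be read on its own: with the chain held fixed, it gives a 3.8-fold higher number from compound 2 to compound 3 (0.58 log units; beyond the scatter), so at this position the chloro group goes with the stronger inhibitor of this pair. The chain can also be read on its own: with the methylamino group held fixed, ethyl in place of hydrogen on a saturated chain carbon, nine bonds along the chain from an aromatic nitrogen, gives a 3.2-fold higher number from compound 1 to compound 3 (0.50 log units; beyond the scatter), so the longer chain goes with the weaker inhibitor here. Compound 1 and compound 2 differ in two places and so could show neither change alone, and nothing measured here says what lies behind either step.

Going by these compounds, it remains open whether the chloro group would give a step of similar size and direction on the shorter chain of compound 1. On these data alone, it is also open how a plain amine or a methoxy group on the same aromatic carbon would read, and whether a still longer chain would continue the direction seen with the methylamino group.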